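Compound 2 to compound 3: a benzyl swap

This account rests on a few compounds, and the source may have more. Where it says the series, first, only, none or still open, it means among the compounds named here.

Working notes on the series, read in an ADME assay on 2209-23 cells (Homo sapiens) for cytotoxicity, read by WST assay and thymidine incorporation; a higher number here means that more compound is tolerated, a lower number that less compound is tolerated. Compound 1 (`CC(C)(C)CCN1C(=O)C(C2=CS(=O)(=O)c3cc(NS(C)(=O)=O)ccc3N2)=C(O)[C@@H]1C(C)(C)C`) gives > 50000 nM, which is a limit of the assay and not a number. Compound 2 (`CC(C)(C)[C@H]1C(O)=C(C2=CS(=O)(=O)c3cc(NS(C)(=O)=O)ccc3N2)C(=O)N1Cc1ccc(F)cc1F`) gives > 50000 nM, which is likewise a limit and not a number. Compound 2 therefore has no exact position in the series, and the two compounds share the same limit (the limit of > 50000 nM in this assay, at which 2 of the 2 values shown sit).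

Compound 3 (`Cc1cc(CN2C(=O)C(C3=CS(=O)(=O)c4cc(NS(C)(=O)=O)ccc4N3)=C(O)[C@@H]2C(C)(C)C)ccc1F`) carries 4-fluoro-3-methylphenyl in place of 2,4-difluorophenyl on a saturated chain carbon bound to an amide-type nitrogen in a ring. The same difference reads 2,4-difluorobenzyl to 4-fluoro-3-methylbenzyl.

For the measured compounds named here, only one measured step changes this same place: a step that the two limits leave unreadable from compound 1 to compound 2. Its size cannot be read, as both ends are limits, so it gives no measure for the new change. It does show that the same limit was reported for both substituents at this place. No step beyond the scatter is therefore expected in this assay, and no direction is expected. The expected step is a number no higher from compound 2 to compound 3 (the limit leaves the size open). For compound 3 the estimate is 50000 nM, with an expected range of 25000 nM to 100000 nM.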

Compound 3, half-maximal cytotoxic concentration: > 50000 nM
Compound 3 ended at the assay's limit; the forecaster's own chance of this, stated with the estimate: 85%; the middle value sits exactly at the limit.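

No step can be read among compound 1, compound 2 and compound 3 in this assay, since each result is a limit and not a number: the limit of > 50000 nM in this assay, at which 3 of the 3 values shown sit.

The compounds shown leave open whether neopentyl, 2,4-difluorobenzyl and 4-fluoro-3-methylbenzyl differ at all at this place in this assay.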